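The source may hold more compounds than are shown below. What is called first, only, known or untested is meant among the compounds shown, and "the series" means these compounds.

The measured compounds, each with its result:

Compound 1 `Cc1ccc(-c2nc3ccc(Br)cn3c2/C=N/OCc2cn(Cc3ccc([N+](=O)[O-])cc3)nn2)cc1`: in a functional assay on the whole organism (strain NMRI) with Mus musculus as the target, with a stated time of 4 h (a higher number here means that more compound is needed for the effect, a lower number that less compound is needed), compound 1 gives 20 mg/kg.
Compound 2 `COc1ccc(Cn2cc(CO/N=C/c3c(-c4ccc(C)cc4)nc4ccc(Br)cn34)nn2)cc1`: compound 2 gives 40 mg/kg.
Compound 3 `Cc1ccc(Cn2cc(CO/N=C/c3c(-c4ccc(C)cc4)nc4ccc(Br)cn34)nn2)cc1`: compound 3 gives 100 mg/kg.

Among these three numbers compound 2 holds the second highest. Its nearest neighbour is compound 1, with a 2.0-fold higher number from compound 1 to compound 2 (0.30 log units; within the scatter), a gap that stays within the usual scatter, so the two cannot be told apart. Its furthest neighbour is compound 3, with a 2.5-fold higher number from compound 2 to compound 3 (0.40 log units; beyond the scatter), a gap that lies beyond the scatter.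

Compound 4 `COc1ccc(Cn2cc(CO/N=C/c3c(-c4ccccc4)nc4ccc(Br)cn34)nn2)cc1` differs from compound 2 in one place: hydrogen in place of methyl on an aromatic carbon.

All three measured steps, a 2.0-fold higher number from compound 1 to compound 2 (0.30 log units; within the scatter), a 5.0-fold higher number from compound 1 to compound 3 (0.70 log units; beyond the scatter) and a 2.5-fold higher number from compound 2 to compound 3 (0.40 log units; beyond the scatter), swap the group on the ring that carries the benzyl attached to the triazole; none alters the 4-methylphenyl on the shared core. Among the compounds with values here, no measured step therefore bears directly on the change from compound 2 to compound 4, and the measured compounds show that small changes of this kind can shift the number by a modest amount or not at all.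

With nothing pointing in either direction, compound 4 is expected to sit close to compound 2, giving no change at the digits printed from compound 2 to compound 4 (within the scatter). The estimated value for compound 4 is 40 mg/kg, with a range from 15 mg/kg to 100 mg/kg.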

Compound 4, minimum effective dose: 40 mg/kg
For compound 4 middle estimate and measured number coincide at the digits printed; the measured number falls inside the stated range.
By their numbers in this assay, from the lowest: compounds 1, 2 and 4 (each within the scatter of the next); then compound 3.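

Within the data shown here, compound 4 is the first compound here with a change on the shared core rather than on the ring of the benzyl group: replacing 4-methylphenyl with phenyl, a swap of methyl for hydrogen para to a large group, gives (no change at the digits printed from compound 2 to compound 4 (within the scatter)) in this assay. At this position, with methoxy on the benzyl ring, removing the methyl therefore has no effect that can be told from the scatter, whereas a one-place swap on the benzyl ring can move the number beyond it (a 5.0-fold higher number from compound 1 to compound 3 (0.70 log units; beyond the scatter)). Nothing measured here gives a reason for this result.

On these data alone, it remains open whether the swap from 4-methylphenyl to phenyl would behave in the same way with nitro or methyl on the benzyl ring, since this single pair carries methoxy there. Also open, as far as these compounds go, is how the minimum effective dose would respond to a different group at this position, such as an amine, a carboxylic acid or a longer alkyl chain, since methyl and hydrogen are the only two substituents compared here.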